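Changing the aryl ring of a urea: from compound 2 to compound 3

This account rests on a few compounds, and the source may have more. Where it says the series, first, only, none or still open, it means among the compounds named here.

The measured compounds so far:
In an assay on isolated protein for binding affinity to 5-hydroxytryptamine receptor 1B (Homo sapiens) (a higher number here means a weaker inhibitor, a lower number a stronger inhibitor), compound 1 `COc1cc2c(cc1N1C[C@@H](C)N(C)[C@@H](C)C1)N(C(=O)c1cccc(Cl)c1)CC2` gives 20 nM.
In this assay compound 2 `COc1cc2c(cc1N1C[C@@H](C)N(C)[C@@H](C)C1)N(C(=O)Nc1cccc(Cl)c1F)CC2` gives 7.94 nM.

Compound 2 holds the lowest of the two numbers shown; its nearest neighbour is compound 1, reached by the step of a 2.5-fold lower number from compound 1 to compound 2 (0.40 log units; beyond the scatter), which is modest but beyond the scatter. Compound 3 `COc1cc2c(cc1N1C[C@@H](C)N(C)[C@@H](C)C1)N(C(=O)Nc1cccc(C(F)(F)F)c1Cl)CC2` has not yet been measured. It differs from compound 2 by 2-chloro-3-(trifluoromethyl)phenyl in place of 3-chloro-2-fluorophenyl on an amide-type nitrogen.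

Among the compounds with values here, only one step has been measured, and it does not test this kind of change: from compound 1 to compound 2 both the link to the carbonyl and the ring substitution were altered at once, so there is no earlier example of exchanging one substituted phenyl for another on the urea nitrogen. Without such a precedent the safest expectation is a number close to that of compound 2, and no step beyond the scatter in this assay. The expected step of a 1.0-fold higher number from compound 2 to compound 3 (0.00 log units; within the scatter) is therefore small. Compound 3 is estimated at 8 nM, with a range from 3 nM to 25 nM.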

Compound 3, inhibition constant: 2.51 nM
Compound 3: the middle estimate sits 3.2-fold (0.50 log units) above what was measured; the whole stated range lies above it.
By their numbers in this assay, from the lowest: compound 3; then compound 2; then compound 1.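

Exchanging one substituted phenyl for another on the urea nitrogen, with nothing else altered, gives a 3.2-fold lower number from compound 2 to compound 3 (0.50 log units; beyond the scatter) in this assay, so this position responds to the aryl group alone and not only to the larger change measured earlier. The group that enters, 2-chloro-3-(trifluoromethyl)phenyl, has 11 heavy atoms against 8 in 3-chloro-2-fluorophenyl, and in this one pair the larger group goes with a lower number, not a higher one. No measurement here explains the step, and the fluorine and chlorine pattern and the trifluoromethyl group change together, so the gain cannot be assigned to any one of them.

Still open, from the compounds shown here alone, is how much each substituent contributes on its own, which a phenyl ring carrying only the chlorine or only the trifluoromethyl group would help to separate. Also open, going by these compounds, is how this position would respond to a group of another kind in place of trifluoromethyl, such as a nitrile, an amine or a carboxylic acid.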